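Swapping methoxycarbonyl for phenyl in compound 3

A few compounds are considered here, and "the series" means these few. Any claim that something is new, unique, unknown or untested is made for them only; others in the source may bear on it.

Measured in a functional assay on the whole organism for inhibition, with Rattus norvegicus as the target; on this read-out lower numbers stand for an effect already at smaller amounts and higher numbers for an effect only at larger amounts of compound:
- Compound 1 `O=C1COCC(=O)N1CCCCN1CCN(c2ncccc2-c2ccccc2)CC1`: > 63 mg/kg (a limit)
- Compound 2 `COc1cccnc1N1CCN(CCCCN2C(=O)SC3(CCCC3)C2=O)CC1`: < 57 mg/kg (a limit)
- Compound 3 `COC(=O)c1cccnc1N1CCN(CCCCN2C(=O)SC3(CCCC3)C2=O)CC1`: 50.2 mg/kg

Compound 3 is the only one of the three with an actual number, 50.2 mg/kg, so it cannot be ranked firmly against the others. Compound 1 and compound 2 are each reported only as a limit.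

Compound 4 `O=C1SC2(CCCC2)C(=O)N1CCCCN1CCN(c2ncccc2-c2ccccc2)CC1` has phenyl in place of methoxycarbonyl on an aromatic carbon of compound 3: phenyl in place of methoxycarbonyl on an aromatic carbon.

Going by the values given here, the one measured step, a step that the limit leaves unreadable from compound 2 to compound 3, swaps methoxy for methoxycarbonyl on an aromatic carbon, and it gives no size to carry over. Compound 1 carries the same phenyl but differs elsewhere, and its result is a limit, > 63 mg/kg.

The estimate therefore rests mainly on compound 3 at 50.2 mg/kg. No step beyond the usual scatter is expected in this assay, and no direction can be favoured. The expected change is a 1.1-fold higher number from compound 3 to compound 4 (0.04 log units; within the scatter). Compound 4 is expected at about 55 mg/kg. The estimated range for compound 4 runs from 25 mg/kg to 120 mg/kg, and the assay may again report only a limit.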

Compound 4, dose for half-maximal effect: > 100 mg/kg
Compound 4 gave a limit, no number (the forecaster's own chance of this, stated with the estimate: 45%); middle value at least 1.8-fold (0.25 log units) away from the limit.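

In this assay, putting phenyl on this aromatic carbon, two atoms from the ring nitrogen, gives an at least 1.9-fold higher number from compound 3 to compound 4 (0.29 log units; that floor lies within the scatter), and the comparison with methoxy gives an at least 1.7-fold higher number from compound 2 to compound 4 (0.24 log units; that floor lies within the scatter). Each of these steps is only a floor and not a measured size, because compound 4 is reported only as a limit: the limit of > 100 mg/kg in this assay, at which 1 of the 4 values shown sits.

Even so, the result adds something new about this position: of the three groups placed here, only phenyl, a six-membered aromatic ring of carbon only with no hydrogen-bond acceptors, gives a result with a lower bound and no upper one, although the data do not establish why.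

The steps from compound 2 to compound 3 and from compound 1 to compound 4 cannot be read, so the compounds shown give no size for the methoxy-to-methoxycarbonyl swap or for the change of the group on the saturated chain. They also leave open how the true dose of compound 4 compares with that of compound 3, and whether a nitrile, an amine or a carboxylic acid at this position would give a measurable dose.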